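Replacing Ureido with Ethoxycarbonyl on a Shared Core

This account rests on a few compounds, and the source may have more. Where it says the series, first, only, none or still open, it means among the compounds named here.

Compound 1, `CCN(C)/N=N/c1ccc(NC(N)=O)cc1`: 3.87
Compound 2, `CCCCN(C)/N=N/c1ccccc1C(N)=O`: 3.1

Of the compounds shown here, two have been measured in a functional assay on L1210 cells (Mus musculus) for antiproliferative activity; a higher number here means a more potent compound, by a factor of ten per unit of this negative logarithm, a lower number a less potent compound. Compound 1 gives 3.87, the higher of the two numbers. Compound 2 gives 3.1, which lies below compound 1 by a gap beyond the usual scatter. Compound 1 and compound 2 differ in more than one place. Among the measured compounds shown here, no single structural step between them can be read from these two values.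

Compound 3, `CCOC(=O)c1ccc(/N=N/N(C)CC)cc1`, differs from compound 1 in one place only: ethoxycarbonyl in place of ureido on an aromatic carbon. For the measured compounds named here, no measured pair shows what this exchange does, so the expectation rests on compound 1 alone. Compound 3 is expected to give about 3.7, in a range from 3.1 to 4.3. The step of a number 0.17 log units lower from compound 1 to compound 3 (within the scatter) is expected to be small, not clearly beyond the scatter in either direction.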

Compound 3, logarithm of the reciprocal of the active concentration, log(1/C): 3.01
Compound 3: middle estimate off by 0.69 log units, on the high side; measured number outside the range, below it.
By their numbers in this assay, from the lowest: compounds 3 and 2 (each within the scatter of the next); then compound 1.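

In this assay, among the compounds shown here, this aromatic carbon is not indifferent to the group it carries: ethoxycarbonyl in place of ureido gives a number 0.86 log units lower from compound 1 to compound 3 (beyond the scatter), the first step in this set that can be read from a single change. Of these two groups, ureido therefore gives the higher number at this position on this core. The exchange also removes 2 hydrogen-bond donors and adds 1 heavy atom, but no measurement here links the step to either difference or to any other cause.

An amine, a carboxylic acid or an acetamido group on this aromatic carbon could land nearer compound 1 or nearer compound 3, and the compounds shown do not settle which. Also open, going by these compounds, is whether the same exchange would give a similar step on a core with a longer chain in place of the ethyl group.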